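Compound 3 to compound 4: a step from a limit

The source may report more compounds than this note shows. Statements on the series, on what has been measured and on what is new or still open speak of the compounds shown alone.

Measured compounds in a functional assay on MCF cells (Homo sapiens) for antiproliferative activity, with a stated time of 72 h; on this read-out lower numbers stand for stronger inhibition and higher numbers for weaker inhibition (each entry is a limit and not a number)
compound 1 `OC[C@H]1O[C@@H](n2cnc3c(NCc4cccc(Br)c4)ncnc32)[C@H](O)[C@@H]1O` gives > 166000 nM
compound 2 `COc1ccc(CNc2ncnc3c2ncn3[C@@H]2O[C@H](CO)[C@@H](O)[C@H]2O)c(OC)c1` gives > 166000 nM
compound 3 `COc1cc(CNc2ncnc3c2ncn3[C@@H]2O[C@H](CO)[C@@H](O)[C@H]2O)cc(OC)c1` gives > 166000 nM

Compound 3 stands at a limit of this assay (> 166000 nM) and has no readable number. The other two compounds sit at the same limit (the limit of > 166000 nM in this assay, at which 3 of the 3 values shown sit) and so nothing separates the three.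

Compound 4 `Cc1cccc(CNc2ncnc3c2ncn3[C@@H]2O[C@H](CO)[C@@H](O)[C@H]2O)c1O` carries 2-hydroxy-3-methylphenyl in place of 3,5-dimethoxyphenyl on a saturated chain carbon bound to a nitrogen on an aromatic ring. Among the compounds with values here, three measured steps bear on this place: a step that the two limits leave unreadable from compound 1 to compound 2 and a step that the two limits leave unreadable from compound 1 to compound 3 and a step that the two limits leave unreadable from compound 2 to compound 3 in this assay. None has a readable size, and none involves the entering group. Within the data shown here, no step of definite size or direction can therefore be derived from them. The likeliest expected outcome is that compound 4 also reaches the limit, with some chance of a measurable value under it. The estimated change is a number no higher from compound 3 to compound 4 (the limit leaves the size open) and it remains an expectation only. Compound 4 is estimated at 166000 nM with an expected range of 30000 nM to 166000 nM in this read-out.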

Compound 4, half-maximal inhibitory concentration: 6900 nM
Compound 4: middle estimate off by 24-fold (1.38 log units), on the high side, outside the stated range (below it).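

In this assay the position on a saturated chain carbon bound to a nitrogen on an aromatic ring now gives a readable value: with 2-hydroxy-3-methylphenyl in place, compound 4 falls under the limit shared by the 3-bromophenyl, 2,4-dimethoxyphenyl and 3,5-dimethoxyphenyl compounds. Against those compounds the change is an at least 24-fold lower number from compound 3 to compound 4 (1.38 log units; beyond the scatter) and an at least 24-fold lower number from compound 2 to compound 4 (1.38 log units; beyond the scatter) and an at least 24-fold lower number from compound 1 to compound 4 (1.38 log units; beyond the scatter) and so the aryl group at this place can move the read-out on an unchanged core, which the earlier compounds, all at one limit, could not show. Each size is a bound and not a measured gap, because compounds 1, 2 and 3 carry no number: the limit of > 166000 nM in this assay, at which 3 of the 4 values shown sit.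

Going by these compounds, the hydroxy and the methyl enter together in compound 4, so the shares of each in the step remain unknown. Also open, on these data alone, is how an amine or a carboxylic acid in place of that hydroxy would read in this assay and whether any such group would carry the value further down.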